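The source may hold more compounds than are shown below. What is called first, only, known or untested is meant among the compounds shown, and "the series" means these compounds.

Compound 1 `O/N=C(\CCN1CCN(c2ccccn2)CC1)c1ccccc1Cl` and compound 2 `O/N=C(\CCN1CCN(c2ccccn2)CC1)c1cccc(F)c1` share the same core and differ only in the ring attached to the carbon with a double bond to nitrogen. In a functional assay on HEK293 cells with D(4) dopamine receptor (Homo sapiens) as the target, read by FLIPR (on this read-out higher numbers stand for an effect only at larger amounts of compound and lower numbers for an effect already at smaller amounts), compound 1 gives 24 nM. In this assay compound 2 gives 17.1 nM. The step of a 1.4-fold lower number from compound 1 to compound 2 (0.15 log units; within the scatter) is the only one measured so far and it lies within the usual scatter, so compound 1 holds the higher of the two numbers without being separated from compound 2.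

Compound 3 `CO/N=C(\CCN1CCN(c2ccccn2)CC1)c1ccccc1Cl` keeps the 2-chlorophenyl ring of compound 1 and is altered elsewhere: methyl in place of hydrogen on an oxygen, so that hydroxy becomes methoxy. Going by the values given here, no measured step touches this oxygen; the single step available, a 1.4-fold lower number from compound 1 to compound 2 (0.15 log units; within the scatter), concerns the ring and gives no guidance here. With nothing measured pointing in either direction, the expectation for compound 3 is a number close to that of compound 1, with a wide range to reflect the missing evidence. Compound 3 is estimated at 30 nM in this assay, between 6 nM and 150 nM, which would mean an expected step of a 1.3-fold higher number from compound 1 to compound 3 (0.10 log units; within the scatter) that stays within the scatter.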

Compound 3, half-maximal effective concentration: 42.3 nM
For compound 3 the middle estimate is 1.4-fold (0.15 log units) below the measured one, within the range that was stated.
By their numbers in this assay, from the lowest: compounds 2, 1 and 3 (each within the scatter of the next, the first and the last beyond it).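

On the oxygen whose other neighbour is the double-bonded nitrogen, methyl in place of hydrogen gives, in this assay, a 1.8-fold higher number from compound 1 to compound 3 (0.25 log units; within the scatter) and so leaves the two compounds unseparated. Going by these compounds alone, this is the first measured change at this oxygen, as the earlier step concerned only the ring, and it shows that, with the 2-chlorophenyl ring kept, hydroxy can become methoxy without the result moving clear of the differences expected between repeated measurements. No available evidence accounts for the size of this step.

This single pair cannot show whether larger groups on the same oxygen, such as ethyl, benzyl or a longer chain ending in a carboxylic acid, would also stay within the scatter of compound 1, so the tolerance of this position is known for methyl only. From the compounds shown here alone, it is also open whether methoxy would give a similar step when paired with the 3-fluorophenyl ring of compound 2, since the change has been read with the 2-chlorophenyl ring alone.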